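A few compounds are considered here, and "the series" means these few. Any claim that something is new, unique, unknown or untested is made for them only; others in the source may bear on it.

Working notes on the series.

Of the compounds shown here, three have been tested in a functional assay on the whole organism (artery, strain albino) with Rattus norvegicus as the target, with a stated time of 60 min, at a dose of 10 mg/kg by the oral route (a lower number here means less inhibition, a higher number more inhibition at the dose given (going by the name of the read-out)), so far. Compound 1, `COc1ccc(C2N=C(SCc3ccccc3Cl)NC(C)=C2C(=O)Nc2ccc(F)cc2)cc1OC`, gives 11.8% in this assay. Compound 2, `COc1ccc(C2N=C(SCc3cccc(Cl)c3)NC(C)=C2C(=O)Nc2ccc(F)cc2)cc1OC`, is its counterpart with 3-chlorophenyl in place of 2-chlorophenyl on a saturated chain carbon bound to a sulfur; in this assay compound 2 gives 8.2%. The step of a number 3.6 percentage points lower from compound 1 to compound 2 (within the scatter) lies within the scatter, so the two numbers are not distinguished by this assay.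

Compound 3, `CC1=C(C(=O)Nc2ccc(Br)cc2)C(c2ccc(Cl)cc2Cl)N=C(SCc2ccccc2Cl)N1`, carries the same sulfanyl-linked group as compound 1 on a different core; the difference between the two cores is not broken down here. In this assay compound 3 gives 11.8%, which stands level with compound 1 at the digits reported and within the scatter of compound 2.

Compound 4, `CC1=C(C(=O)Nc2ccc(Br)cc2)C(c2ccc(Cl)cc2Cl)N=C(SCc2cccc(Cl)c2)N1`, has not yet been measured. It differs from compound 3 by 3-chlorophenyl in place of 2-chlorophenyl on a saturated chain carbon bound to a sulfur, at the same place as in the pair already tested, so it is the same change made a second time on the other core. Among the measured compounds shown here, the only guide to its effect is the earlier pair, where a number 3.6 percentage points lower from compound 1 to compound 2 (within the scatter) stayed within the scatter. On that basis the step is expected to be small, estimated as a number 2.8 percentage points lower from compound 3 to compound 4 (within the scatter). Compound 4 is accordingly expected to give about 9% in this assay, estimated to fall between 2% and 18%. Whether the second core changes the size of this step cannot be told from one pair.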

Compound 4, a percentage reported as inhibition, in the whole organism at one dose (the size of the read-out at that dose, not a potency): 6.2%
Compound 4: the middle estimate sits 2.8 percentage points above what was measured; the range from low to high includes it.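

In this assay, the exchange of 2-chlorophenyl for 3-chlorophenyl on a saturated chain carbon bound to a sulfur, carried out on the core of compound 3, gives a number 5.6 percentage points lower from compound 3 to compound 4 (within the scatter), so the assay does not distinguish these two numbers. Set beside the same exchange on the core of compound 1, the second step agrees with the first as far as the measurements can tell: the same change on two cores in this assay, a number 3.6 percentage points lower (within the scatter) from compound 1 to compound 2 and a number 5.6 percentage points lower (within the scatter) from compound 3 to compound 4, 2 percentage points apart, within the scatter of two such steps. Among the compounds shown here, neither step stands clear of the scatter, so the two pairs show only that the exchange is not resolved on either core; they do not show that a real effect of it carries from one core to the other, and they say nothing about any further core.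

The compounds shown leave open how this assay responds when the group on the sulfur is something other than 2-chlorobenzyl or 3-chlorobenzyl, for instance a longer chain ending in an amine or a carboxylic acid. Also open, going by these compounds, is what each part of the difference between the two cores contributes, as compound 1 and compound 3 differ in more than one place and their numbers cannot be assigned to any single part.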